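The compounds below may be only part of what the source reports. "The series", "measured", "known", "first", "only" and "open" are said of these compounds alone.

In an assay on isolated protein for binding affinity to Alpha-1B adrenergic receptor (Homo sapiens), read by radioligand binding (on this read-out lower numbers stand for stronger inhibition and higher numbers for weaker inhibition), the three measured compounds span a clear range. Compound 1, `COc1ccc(Cl)cc1N1CCN(CCNc2c(C(C)=O)c(-c3ccccc3)nn(C)c2=O)CC1`, gives 3.95 nM, the lowest of the three numbers and therefore the strongest binding seen here. Compound 2, `COc1ccccc1N1CCN(CCCNc2c(C(C)=O)c(-c3ccccc3)nn(C)c2=O)CC1`, gives 20.3 nM, a number beyond the usual scatter of compound 1. Compound 3, `COc1ccccc1N1CCN(CCNc2cc(C)nn(C)c2=O)CC1`, gives 33.1 nM, the furthest from compound 1 and also beyond the scatter. Compound 1 thus stands alone at the strong end of this assay.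

Compound 4, `CC(=O)c1c(-c2ccccc2)nn(C)c(=O)c1NCCN1CCN(c2ccccc2Cl)CC1`, has not been measured in this assay. It differs from compound 1 in one place: 2-chlorophenyl in place of 5-chloro-2-methoxyphenyl on an amine nitrogen in a ring. The hydrogen-bond acceptor that the leaving group carried is absent from the entering group, and the entering group is two heavy atoms smaller.

For the measured compounds named here, no measured pair that differs in exactly this way is available, so the size of the step is uncertain. A modest weakening in this assay is expected for compound 4, with the step from compound 1 to compound 4 estimated at a 2.0-fold higher number from compound 1 to compound 4 (0.31 log units; beyond the scatter), which lies near the edge of the scatter rather than far beyond it. On that basis compound 4 is estimated at 8 nM, in a range from 2.5 nM to 25 nM.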

Compound 4, inhibition constant: 0.75 nM
Compound 4: middle estimate off by 11-fold (1.03 log units), on the high side, and the stated range ends above it.
By their numbers in this assay, from the lowest: compound 4; then compound 1; then compounds 2 and 3 (each within the scatter of the next).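

In this assay, for the compounds shown here, the step of a 5.3-fold lower number from compound 1 to compound 4 (0.72 log units; beyond the scatter) is the first comparison here in which only the aryl group on the amine nitrogen in the ring changes, and it shows that the number at this position moves beyond the scatter with that group alone. Its direction also shows that, on the core of compound 1, the larger 5-chloro-2-methoxyphenyl with its hydrogen-bond acceptor is not needed for a low number, since the smaller 2-chlorophenyl, which has no such acceptor, reads lower still. This holds for this one pair only, and nothing measured alongside it speaks to why the number moves this way.

The two groups differ in both the methoxy and the way the chlorine is placed on the ring, so this single step cannot say how much of the change belongs to each. Going by these compounds alone, also open is how a 2-fluorophenyl, a 2-methylphenyl or an unsubstituted phenyl on the same nitrogen would read on this core, and whether the same exchange would move the number in the same direction on a longer chain such as the one in compound 2.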